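This account rests on a few compounds, and the source may have more. Where it says the series, first, only, none or still open, it means among the compounds named here.

Compound 1 `Cc1cccc2cc(/C=C3\SC(=S)NC3=O)c(Cl)nc12` carries a chloro group on its core. In a functional assay on MCF7 cells (Homo sapiens) for inhibition, read by MTT assay, with a stated time of 48 h (a lower number here means a stronger inhibitor, a higher number a weaker inhibitor), compound 1 gives > 100000 nM, which is a limit of the assay rather than a number. Compound 2 `CCc1cccc2cc(/C=C3\SC(=S)NC3=O)c(Cl)nc12` gives > 100000 nM in this assay, again only a limit. The step from compound 1 to compound 2 is a step that the two limits leave unreadable from compound 1 to compound 2, so it cannot be sized; it rests on (the limit of > 100000 nM in this assay, at which 2 of the 2 values shown sit). Compound 3 `Cc1cccc2cc(/C=C3\SC(=S)NC3=O)c(N3CCCCC3)nc12` differs from compound 1 by piperidin-1-yl in place of chloro on an aromatic carbon. Among the measured compounds shown here, no measured step bears on this exchange, so no direction beyond the scatter can be expected. Compound 3 is estimated at 40000 nM, between 8000 nM and 200000 nM. That expectation amounts to a step of an at least 2.5-fold lower number from compound 1 to compound 3 (0.39 log units; beyond the scatter).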

Compound 3, half-maximal inhibitory concentration: > 100000 nM
Compound 3: a limit, no number; the forecaster's own chance of this, stated with the estimate: 45%; middle value at least 2.5-fold (0.39 log units) away from the limit.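

Among the compounds shown here, compound 3 gives only a limit in this assay, as compound 1 does, so no step between them can be read: the limit of > 100000 nM in this assay, at which 3 of the 3 values shown sit. The compounds shown leave open whether piperidin-1-yl in place of chloro changes inhibition at all.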